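The source may report more compounds than this note shows. Statements on the series, on what has been measured and on what is new or still open speak of the compounds shown alone.

In a functional assay on A549 cells (Homo sapiens) for cytotoxicity, read by MTT assay, with a stated time of 24 h (a higher number here means a weaker inhibitor, a lower number a stronger inhibitor), compound 1 `CCOC(=O)N1CCC(=NNC(=O)c2ccc(Cl)cc2)CC1` gives only a limit, > 400000 nM. Compound 2 `CCOC(=O)N1CCC(=NNC(=O)c2ccc([N+](=O)[O-])cc2)CC1` likewise stands at a limit, > 400000 nM. The step that the two limits leave unreadable from compound 1 to compound 2 therefore cannot be read. Compound 3 `O=C(NN=C1CC(c2ccccc2)NC(c2ccccc2)C1)c1ccccc1` also reaches no number in this assay; its value is the limit > 400000 nM. the limit of > 400000 nM in this assay, at which 3 of the 3 values shown sit, describes the position of all three. Compound 4 `COc1ccc(C(=O)NN=C2CC(c3ccccc3)NC(c3ccccc3)C2)cc1` differs from compound 3 by methoxy in place of hydrogen on an aromatic carbon. Among the measured compounds shown here, no measured step follows this change, and the one step recorded, chloro to nitro, is itself unreadable, so no size in either direction can be expected beyond the scatter, and compound 3 offers only a limit as a starting point. Compound 4 is expected to remain at or near that limit, with a step that the limit leaves unreadable from compound 3 to compound 4 expected to be nominal. For compound 4 the half-maximal inhibitory concentration in this assay is estimated at 600000 nM, with a range from 200000 nM to 2000000 nM.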

Compound 4, half-maximal inhibitory concentration: > 400000 nM
Compound 4: only a limit was reported (the forecaster's own chance of this, stated with the estimate: 80%); the middle value lies beyond the limit too.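

In this assay, among the compounds shown here, compound 3 and compound 4 both stand only at a limit, so no step between them can be read. How the compounds shown rank against one another stays open, as all share one limit: the limit of > 400000 nM in this assay, at which 4 of the 4 values shown sit.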